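The compounds below may be only part of what the source reports. "The series", "measured", "known", "first", "only" and "open" are said of these compounds alone.

Compound 1 `O=C1OC(CO)Cc2ccccc21` sits at the limit of a functional assay on PC-3 cells (Homo sapiens) for antiproliferative activity, read by sulforhodamine B assay, with a stated time of 48 h (on this read-out higher numbers stand for weaker inhibition of growth and lower numbers for stronger inhibition of growth), recorded as >= 250 ug/mL rather than as a number.
Compound 2 `COc1ccc2c(c1)C(=O)OC(CO)C2` gives 175 ug/mL in this assay.
Compound 3 `COc1ccc2c(c1)C(=O)OC(CCCO)C2` gives 70.7 ug/mL in this assay.

Of the two compounds that returned a number, compound 3 holds the lower one; its nearest neighbour is compound 2, and the step of a 2.5-fold lower number from compound 2 to compound 3 (0.39 log units; beyond the scatter) lies beyond the scatter. Compound 4 `CCCCCOCCCC1Cc2ccc(OC)cc2C(=O)O1` differs from compound 3 in one place: pentyl in place of hydrogen on an oxygen on a saturated carbon. For the measured compounds named here, no measured step makes exactly this change. The step of an at least 1.4-fold lower number from compound 1 to compound 2 (0.15 log units; that floor lies within the scatter) touched a different part of the molecule and stays within the scatter, so it says little here. The step of a 2.5-fold lower number from compound 2 to compound 3 (0.39 log units; beyond the scatter), which put 2-hydroxyethyl in place of hydroxy, is the closer parallel, since it too added carbon to the chain that carries the oxygen, and it lowered the number modestly. On that single precedent a further modest lowering is expected, about a 2.0-fold lower number from compound 3 to compound 4 (0.31 log units; beyond the scatter), though the precedent is thin. The expected value for compound 4 in this assay is 35 ug/mL, with a range from 12 ug/mL to 110 ug/mL.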

Compound 4, concentration for 50% growth inhibition: 29.5 ug/mL
Beside the measured number, compound 4's estimate is 1.2-fold (0.07 log units) above it; the measured number falls inside the stated range.
By their numbers in this assay, from the lowest: compound 4; then compound 3; then compound 2. At a limit, above all of these: compound 1.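

Putting pentyl in place of hydrogen on this oxygen gives a 2.4-fold lower number from compound 3 to compound 4 (0.38 log units; beyond the scatter) in this assay. Compound 1, compound 2 and compound 3 all carry a hydroxy group, so compound 4 is the first case shown in which that hydroxy is gone, and the number still falls, showing that growth inhibition in this series does not depend on keeping the hydroxy hydrogen. The data shown do not explain why this change lowers the number.

Still open, going by these compounds, is whether the length of the pentyl chain matters or whether replacing the hydrogen is enough, a question that a methyl or a longer chain such as octyl on the same oxygen could answer. An amine in place of the oxygen would show whether the oxygen itself is needed.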